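This account rests on a few compounds, and the source may have more. Where it says the series, first, only, none or still open, it means among the compounds named here.

Two compounds of this series carry a number in an ADME assay on A549 cells (Homo sapiens) for cytotoxicity, read by CellTiter-Glo (a lower number here means that less compound is tolerated, a higher number that more compound is tolerated), so far. Compound 1 `Cc1c(Cc2ccccc2)c(=O)oc2cc(OCC(O)CNCCCO)ccc12` gives 53400 nM in this assay. Compound 2 `Cc1c(Cc2ccc(F)cc2)c(=O)oc2cc(OCC(O)CN3CCC(C(N)=O)CC3)ccc12` gives 89300 nM in this assay; this is the higher of the two numbers, but the gap to compound 1 lies within the scatter of the measurement, so the two compounds are not told apart on what is known.

Compound 3 `COc1ccc(Cc2c(C)c3ccc(OCC(O)CN4CCC(C(N)=O)CC4)cc3oc2=O)c(Br)c1` has not yet been run. It is built from compound 2 by one change at the benzyl arm: 2-bromo-4-methoxyphenyl in place of 4-fluorophenyl on a saturated chain carbon bound to an aromatic carbon. Going by the values given here, no pair of measured compounds shows the effect of a change at this position, so there is no measured step to lean on; both measured numbers sit at the high end of the concentration range and differ only within the scatter, which argues for a modest shift at most.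

On that basis compound 3 is expected to give 70000 nM in this assay, with a range from 30000 nM to 150000 nM. The step from compound 2 to compound 3 is thus estimated as a 1.3-fold lower number from compound 2 to compound 3 (0.11 log units; within the scatter), a move not expected to exceed the scatter, though the direction is uncertain.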

Compound 3, half-maximal cytotoxic concentration: 44400 nM
Estimate against measurement, compound 3: 1.6-fold (0.20 log units) above, and the stated range covers the measured number.
By their numbers in this assay, from the lowest: compounds 3, 1 and 2 (each within the scatter of the next).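

In this assay the benzyl arm now has its first measured step: 2-bromo-4-methoxyphenyl in place of 4-fluorophenyl on a saturated chain carbon bound to an aromatic carbon gives a 2.0-fold lower number from compound 2 to compound 3 (0.30 log units; within the scatter) with the rest of the structure held constant. Compounds 1 and 2 differ in more than one place and could not isolate this position, whereas compound 2 and compound 3 show that this exchange of aryl groups, which brings in a bromine and a methoxy group and one hydrogen-bond acceptor where the leaving group has none, does not move the number beyond the scatter. The statement rests on this single pair, and nothing available explains the result or bears on it.

The combined 2-bromo-4-methoxyphenyl group leaves the contributions of the bromine and the methoxy group unseparated, so 2-bromophenyl and 4-methoxyphenyl on the same arm would be the direct comparisons. On these data alone, it also remains open whether this position stays as flat with a charged group on the aryl ring, such as an amine or a carboxylic acid.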